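Notes on the shared core: from compound 1 to compound 4

The compounds below may be only part of what the source reports. "The series", "measured", "known", "first", "only" and "open" are said of these compounds alone.

Measured so far:
compound 1 `Cc1ccc(S(=O)(=O)Nc2ccc3oc(-c4ccccc4)nc3c2)cc1` — in an assay on isolated protein for inhibition of malate dehydrogenase, mitochondrial (Sus scrofa), with stated times of 45 min and 30 min (on this read-out higher numbers stand for weaker inhibition and lower numbers for stronger inhibition), compound 1 gives > 63000 nM, a limit of the assay.
compound 2 `O=S(=O)(Nc1ccc(-c2nc3ccccc3o2)cc1)c1ccc(Cl)s1` — in this assay compound 2 gives > 63000 nM, again a limit.
compound 3 `CS(=O)(=O)Nc1ccc(-c2nc3ccccc3o2)cc1` — in this assay compound 3 gives > 63000 nM, again a limit.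

Compound 1 stands nowhere that can be ranked: its value is a limit, and the same holds for the other two values shown, since (the limit of > 63000 nM in this assay, at which 3 of the 3 values shown sit). Going by the values given here, the only step between measured compounds that differ in one place, a step that the two limits leave unreadable from compound 2 to compound 3, is unreadable for the same reason, so its size is unknown.

The step under study is hydroxy in place of methyl on an aromatic carbon, giving compound 4 `O=S(=O)(Nc1ccc2oc(-c3ccccc3)nc2c1)c1ccc(O)cc1`. Among the compounds with values here, no measured step touches a hydroxy for methyl exchange, and none of the three measurements yields a readable number, so there is no basis for a direction or size beyond the scatter in this assay. Compound 4 is expected at 80000 nM, with a range from 15000 nM to 300000 nM, and most probably the assay again reports only a limit. The step that the limit leaves unreadable from compound 1 to compound 4 is thus expected to be unreadable or, if readable, within the scatter.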

Compound 4, half-maximal inhibitory concentration: > 63000 nM
Compound 4 gave a limit, no number (the forecaster's own chance of this, stated with the estimate: 85%); the middle value lies beyond the limit too.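

In this assay compound 4 gives > 63000 nM, a limit of the assay. The step from compound 1 to compound 4 cannot be read, because both compounds sit at that limit: the limit of > 63000 nM in this assay, at which 4 of the 4 values shown sit.

The compounds shown leave open whether hydroxy in place of methyl changes inhibition at all, and whether any compound on this series gives a readable number.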